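The compounds below may be only part of what the source reports. "The series", "measured", "known", "first", "only" and "open" are said of these compounds alone.

Measured so far:
- compound 1, `c1ccc2c(-c3nnc(-c4ccncc4)o3)c[nH]c2c1` — 4100 nM
- compound 2, `COc1ccc(-c2nnc(-c3c[nH]c4ccccc34)o2)cc1` — > 1000000 nM
- compound 3, `COc1cc(-c2nnc(-c3c[nH]c4ccccc34)o2)ccc1OCc1ccccc1` — > 1000000 nM

Going by the values given here, in a functional assay on PC-3 cells (Homo sapiens) for cytotoxicity, read by MTT assay (a higher number here means a weaker inhibitor, a lower number a stronger inhibitor), compound 1 gives 4100 nM, the only actual number among the three values shown. For compound 2 the result is a limit of the assay, > 1000000 nM. For compound 3 the result is likewise a limit, > 1000000 nM. Compound 1 therefore stands alone with a measured number, while the other two sit at the limit of > 1000000 nM in this assay, at which 2 of the 3 values shown sit.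

Compound 4, `FC(F)(F)c1nnc(-c2c[nH]c3ccccc23)o1`, is not yet measured. It differs from compound 1 in one place: trifluoromethyl in place of pyridin-4-yl on an aromatic carbon. Among the compounds with values here, no step between measured compounds is available to calibrate this change. Within the data shown here, since the pyridin-4-yl compound is the one that produced a number in this assay and the two compounds with other groups on the shared core reached only the limit, the expected direction for compound 4 is toward a weaker inhibitor, by a step beyond the scatter. The step from compound 1 to compound 4 is estimated at a 6.1-fold higher number from compound 1 to compound 4 (0.79 log units; beyond the scatter). Compound 4 is thus expected near 25000 nM, between 4000 nM and 300000 nM, with a fair chance that only a limit is reported.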

Compound 4, half-maximal inhibitory concentration: > 1000000 nM
Compound 4: a limit, no number; the forecaster's own chance of this, stated with the estimate: 35%; middle value at least 40-fold (1.60 log units) from the limit.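

Going by these compounds alone, on the carbon of the five-membered aromatic ring that carries pyridin-4-yl in the shared core, replacing that group with trifluoromethyl gives the first readable step at this position in this assay: an at least 240-fold higher number from compound 1 to compound 4 (2.38 log units; beyond the scatter). The result for compound 4 is a limit of the assay and not a number, so this step gives only the smallest size the change can have. The earlier limits came from compounds with larger groups at this position, whereas compound 4 shows that a small group without a ring, and without the hydrogen-bond acceptor of pyridin-4-yl, also reaches the limit, leaving compound 1 as the only compound with a number: the limit of > 1000000 nM in this assay, at which 3 of the 4 values shown sit.

The compounds shown leave open whether the ring nitrogen or the ring itself matters most. Plain phenyl, pyridin-3-yl or an amine at this carbon would begin to separate the two.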